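This account rests on a few compounds, and the source may have more. Where it says the series, first, only, none or still open, it means among the compounds named here.

Of the compounds shown here, three sharing one core have been measured in a functional assay on KYSE-450 cells (Homo sapiens) for inhibition, read by MTT assay, with a stated time of 48 h; on this read-out lower numbers stand for stronger inhibition and higher numbers for weaker inhibition. Compound 1 `C/C=C/C=C/C(=O)N(Cc1ccc(OC)c(O)c1)c1cc(OC)c(OC)c(OC)c1` gives 180 nM, compound 2 `COc1ccc(CN(C(=O)CCCCCl)c2cc(OC)c(OC)c(OC)c2)cc1O` gives 770 nM, and compound 3 `COc1ccc(CN(C(=O)/C=C/CBr)c2cc(OC)c(OC)c(OC)c2)cc1O` gives 100 nM. Compound 3 shows the lowest number of the three, though its gap to compound 1 lies within the scatter; only the gap to compound 2 is beyond it, as seen in the step of a 7.7-fold lower number from compound 2 to compound 3 (0.89 log units; beyond the scatter). The next compound, compound 4 `COCC(=O)N(Cc1ccc(OC)c(O)c1)c1cc(OC)c(OC)c(OC)c1`, differs from compound 3 at the carbonyl carbon: methoxymethyl in place of 3-bromoprop-1-en-1-yl on a carbonyl carbon. Among the compounds with values here, two measured steps bear on this change. The step of a 7.7-fold lower number from compound 2 to compound 3 (0.89 log units; beyond the scatter) shows that the 3-bromoprop-1-en-1-yl group goes with a clearly lower number than a 4-chlorobutyl group on that carbonyl carbon, while the step of a 1.8-fold lower number from compound 1 to compound 3 (0.26 log units; within the scatter) shows that exchanging prop-1-en-1-yl for bromomethyl on the double-bonded chain carbon gives nothing beyond the scatter. Within the data shown here, compound 4 loses the whole 3-bromoprop-1-en-1-yl group and takes methoxymethyl instead, for which no direct precedent exists among the three; the nearest analogy is compound 2, whose carbonyl carbon also carries no double bond outside aromatic rings. Compound 4 is therefore expected to give a higher number than compound 3, a step of about a 7.0-fold higher number from compound 3 to compound 4 (0.85 log units; beyond the scatter). In this assay compound 4 is estimated at 700 nM, with a range from 250 nM to 2000 nM.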

Compound 4, half-maximal inhibitory concentration: 460 nM
Beside the measured number, compound 4's estimate is 1.5-fold (0.18 log units) above it; low and high end bracket the measured number.
By their numbers in this assay, from the lowest: compounds 3 and 1 (each within the scatter of the next); then compounds 4 and 2 (each within the scatter of the next).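

In this assay, methoxymethyl on the carbonyl carbon does not hold what the 3-bromoprop-1-en-1-yl group gives, with a 4.6-fold higher number from compound 3 to compound 4 (0.66 log units; beyond the scatter), and the same group also falls short of the dienyl chain of compound 1, with a 2.6-fold higher number from compound 1 to compound 4 (0.41 log units; beyond the scatter). Against the 4-chlorobutyl chain it makes no difference beyond the scatter, with a 1.7-fold lower number from compound 2 to compound 4 (0.22 log units; within the scatter), so two quite different groups without a double bond outside aromatic rings, one carrying chlorine and the other an ether oxygen, now read alike. Among these four compounds, the two with such a double bond in the group on the carbonyl carbon, compound 1 and compound 3, both give lower numbers than the two without it, and none goes against this, while the bromine of compound 3 is not needed for the low reading, as compound 1 lacks it.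

The compounds shown leave open whether the double bond itself carries this split, which a 3-methoxyprop-1-en-1-yl group or an amine on the same chain would help to test. Nothing given here explains why these groups differ.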